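The source may hold more compounds than are shown below. What is called first, only, known or untested is meant among the compounds shown, and "the series" means these compounds.

Measured so far:
- compound 1 `CNC(=O)/C=C/CNCCOc1ccc(Oc2c(-c3ccc(F)cc3)sc3cc(O)ccc23)cc1` gives 16100 nM
- compound 2 `CN(C)C(=O)/C=C/CN1CC(Oc2ccc(Oc3c(-c4ccc(F)cc4)sc4cc(O)ccc34)cc2)C1` gives 22300 nM

In a functional assay on MCF7 cells (Homo sapiens) for antiproliferative activity, read by CCK-8 assay, with a stated time of 48 h (a lower number here means a stronger inhibitor, a higher number a weaker inhibitor), only these two compounds have numbers, and they cannot be ranked: the gap is a 1.4-fold higher number from compound 1 to compound 2 (0.14 log units; within the scatter). Compound 3 `O=C(/C=C/CNCCOc1ccc(Oc2c(-c3ccc(F)cc3)sc3cc(O)ccc23)cc1)N1CCCCC1` keeps the core and chain of compound 1 and alters only the amide at the end of the chain: piperidin-1-yl in place of methylamino on a carbonyl carbon. In words, methylcarbamoyl becomes (piperidin-1-yl)carbonyl.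

For the measured compounds named here, one measured step bears on this. Compound 2 also gives up the methylcarbamoyl, for dimethylcarbamoyl, and the result is a 1.4-fold higher number from compound 1 to compound 2 (0.14 log units; within the scatter). Going by the values given here, that step changes the chain as well, so it is only a loose guide, and no measured compound carries the piperidin-1-yl group. No shift beyond the scatter is therefore expected in this assay. The estimated step is a 1.1-fold higher number from compound 1 to compound 3 (0.05 log units; within the scatter). For compound 3 the expected value is 18000 nM, with an estimated range from 8000 nM to 40000 nM.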

Compound 3, half-maximal inhibitory concentration: 16400 nM
Estimate against measurement, compound 3: 1.1-fold (0.04 log units) above; low and high end bracket the measured number.
By their numbers in this assay, from the lowest: compounds 1, 3 and 2 (each within the scatter of the next).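

In this assay the swap of methylamino for piperidin-1-yl on the carbonyl carbon gives a 1.0-fold higher number from compound 1 to compound 3 (0.01 log units; within the scatter) and so lies within the scatter. Unlike the earlier step, this one leaves the chain as it was and alters only the group on the carbonyl carbon, so it reads this position alone: six heavy atoms in a six-membered non-aromatic ring stand where two stood, the amide hydrogen is gone, and the number shows no shift beyond the scatter. No available evidence explains this result.

From the compounds shown here alone, whether a morpholin-4-yl group or a plain amino group on the same carbonyl carbon would also stay within the scatter remains open. So does the outcome of replacing the amide with a carboxylic acid.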